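This account rests on a few compounds, and the source may have more. Where it says the series, first, only, none or still open, it means among the compounds named here.

Compound 1 `CC(C(=O)c1cc(C(F)(F)F)nn1-c1ccc2onc(N)c2c1)c1ccc(-c2ccccc2S(C)(=O)=O)cc1F`: in an assay on isolated protein for inhibition of Trypsin (Homo sapiens) (on this read-out higher numbers stand for weaker inhibition and lower numbers for stronger inhibition), compound 1 gives > 20000 nM, which is a limit of the assay and not a number.
Compound 2 `CN(C)Cc1ccccc1-c1ccc(CC(=O)c2cc(C(F)(F)F)nn2-c2ccc3onc(N)c3c2)c(F)c1`: in this assay compound 2 gives > 4200 nM, again only a limit.
Compound 3 `COc1ccc(-n2nc(C(F)(F)F)cc2C(=O)Cc2ccc(-c3ccccc3CN3CC[C@H](O)C3)cc2)cc1`: in this assay compound 3 gives > 4200 nM, again only a limit.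

Compound 2 therefore stands where the whole set stands: no measured number, only a limit. Across the three values there are two kinds of limit, the limit of > 20000 nM in this assay, at which 1 of the 3 values shown sits, and (the limit of > 4200 nM in this assay, at which 2 of the 3 values shown sit), and no step between any two measured compounds can be sized.

Compound 4 `Nc1noc2ccc(-n3nc(C(F)(F)F)cc3C(=O)Cc3ccc(-c4ccccc4S(N)(=O)=O)cc3F)cc12` differs from compound 2 in one place: sulfamoyl in place of (dimethylamino)methyl on an aromatic carbon. Among the measured compounds shown here, with every value a limit, no measured step offers a guide to the effect of this change in this assay. The expectation is that the step from compound 2 to compound 4, a step that the limit leaves unreadable from compound 2 to compound 4, is none beyond the scatter, and that compound 4 again reaches only a limit. The estimate for compound 4 in this assay is 20000 nM, with a range from 4200 nM to 100000 nM.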

Compound 4, inhibition constant: > 20000 nM
Compound 4: only a limit was reported; the forecaster's own chance of this, stated with the estimate: 85%; the middle value lies on the limit itself.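

In this assay compound 4 gives > 20000 nM, a limit of the assay and not a number. Compound 2 also has only a limit, and the step between compound 2 and compound 4 cannot be read. The compounds shown leave open how strongly any of them inhibits, and whether sulfamoyl and (dimethylamino)methyl differ at all in this assay.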